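Swapping a phenyl for a heteroaryl on a weakly active core

A few compounds are considered here, and "the series" means these few. Any claim that something is new, unique, unknown or untested is made for them only; others in the source may bear on it.

Compound 1 `CC(C)c1nn(-c2ccc(C(N)=O)c(N[C@H]3CC[C@H](O)CC3)c2)c2nccc(-c3ccccc3)c12` carries a phenyl on its core, and in a functional assay on SK-BR-3 cells (Homo sapiens) for inhibition, read by CellTiter-Glo, with a stated time of 72 h (on this read-out lower numbers stand for stronger inhibition and higher numbers for weaker inhibition), compound 1 gives only a limit, > 10000 nM, so its true number is not known. Two related compounds carry a nitrogen-rich heteroaryl in the same region: compound 2 `CNc1cc(C(N)=O)ccc1-n1nc(C(C)C)c2c(-n3cnc(-c4cnn(C)c4)c3)ccnc21` gives 419 nM in this assay, and compound 3 `CC(C)c1nn(-c2ccc(C(N)=O)cc2)c2nccc(-n3cnc(-c4cnn(C)c4)c3)c12` gives 1640 nM. The step of a 3.9-fold higher number from compound 2 to compound 3 (0.59 log units; beyond the scatter) shows that removing the methylamino group weakens inhibition.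

Compound 4 `CC(C)c1nn(-c2ccc(C(N)=O)c(N[C@H]3CC[C@H](O)CC3)c2)c2nccc(-n3cnc(-c4cncnc4)c3)c12` is compound 1 with one change: 4-(pyrimidin-5-yl)-1H-imidazol-1-yl in place of phenyl on an aromatic carbon. Within the data shown here, no measured pair shows exactly this change, but compounds 2 and 3 both carry a heteroaryl of this kind and both sit well inside the measurable range, whereas compound 1 sits at the limit of > 10000 nM in this assay, at which 1 of the 3 values shown sits. Compound 4 also keeps the hydroxycyclohexylamino substituent, which resembles the methylamino group whose loss drove the step from compound 2 to compound 3.

On this basis compound 4 is expected to move from the limit into the measurable range, with a step of an at least 28-fold lower number from compound 1 to compound 4 (1.45 log units; beyond the scatter) toward stronger inhibition. The estimated value for compound 4 in this assay is 350 nM, within a range from 70 nM to 2500 nM.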

Compound 4, half-maximal inhibitory concentration: 387 nM
Compound 4: middle estimate off by 1.1-fold (0.04 log units), on the low side; the range from low to high includes it.
By their numbers in this assay, from the lowest: compounds 4 and 2 (each within the scatter of the next); then compound 3. At a limit, above all of these: compound 1.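

On the shared core, with the hydroxycyclohexylamino substituent unchanged, placing 4-(pyrimidin-5-yl)-1H-imidazol-1-yl instead of phenyl on this aromatic carbon, opposite the ring nitrogen, gives an at least 25-fold lower number from compound 1 to compound 4 (1.41 log units; beyond the scatter) in this assay. Among these compounds, compounds 2 and 3 showed that compounds carrying a related heteroaryl could give measurable values, but neither could be compared directly with a phenyl compound, so this pair is the first to tie a large gain to this single change at this position. Compound 1 gives only a limit, so the step sets a minimum size and its true size remains unknown: the limit of > 10000 nM in this assay, at which 1 of the 4 values shown sits.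

The compounds shown leave open which part of the entering group matters, as the pair cannot tell whether the five-membered aromatic ring alone would give the same gain or whether the pyrimidin-5-yl part is also needed. They also leave open how a much smaller group at this carbon, such as a simple amine or a carboxylic acid, would compare with both phenyl and 4-(pyrimidin-5-yl)-1H-imidazol-1-yl.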